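From 2-Methoxyphenyl to 4-Methoxyphenyl: An Expected Outcome

The compounds below may be only part of what the source reports. "The series", "measured", "known", "first", "only" and "open" are said of these compounds alone.

Compound 1 `COc1ccccc1/C=C/C(=O)OC/C=C/c1cc(OC)c(OC)cc1OC` was tested in a functional assay on the whole organism (strain Kunming) with Mus musculus as the target, with a stated time of 0.5 h, at a dose of 300 mg/kg by the intraperitoneal route (on this read-out lower numbers stand for a stronger effect and higher numbers for a weaker effect at the one dose given), and in this assay compound 1 gives 100%. The only other measured compound, compound 2 `COc1cc(OC)c(OC)cc1/C=C/COC(=O)/C=C/c1cc(OC)c(OC)c(OC)c1OC`, gives 100% in this assay, so compound 1 stands level with compound 2 at the digits shown, the two values lying within the scatter of each other. For the measured compounds named here, no step between two measured compounds that differ in one place is available, so the size of a single structural change has not yet been seen.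

Compound 3 `COc1ccc(/C=C/C(=O)OC/C=C/c2cc(OC)c(OC)cc2OC)cc1` has not been measured in this assay. It differs from compound 1 in one place: 4-methoxyphenyl in place of 2-methoxyphenyl on a double-bonded chain carbon bound to a double-bonded chain carbon.

With both measured values already sitting at the same high level, a step from compound 1 to compound 3 of no size beyond the scatter is expected. The read-out of compound 3 is estimated at 97%, with a range from 82% to 100%, which means an expected step of a number 3 percentage points lower from compound 1 to compound 3 (within the scatter).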

Compound 3, a percentage reported as activity, at one dose (the size of the read-out at that dose, not a potency): 100%
Estimate against measurement, compound 3: 3 percentage points below; measured number inside the range.
By their numbers in this assay, from the lowest: compounds 1, 2 and 3 (each within the scatter of the next).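

In this assay, putting 4-methoxyphenyl in place of 2-methoxyphenyl on a double-bonded chain carbon bound to a double-bonded chain carbon gives no change at the digits printed from compound 1 to compound 3 (within the scatter). For the compounds shown here, this is the first step that can be read at a single place, and it shows that this read-out, at this one dose, does not tell apart these two groups, which have the same atoms joined differently. Nothing measured here bears on why the two groups read alike.

On these data alone, all three compounds print the same number, on the side of the scale that stands for a weaker effect, and with a single dose this says nothing about potency, so it remains open whether any group at this place can move the read-out at all. A phenyl ring carrying an amine or a carboxylic acid in place of the methoxy group would test this, as would a longer chain between the ring and the ester carbonyl, and only a compound with a clearly lower number would give this series a step beyond the scatter.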